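The compounds below may be only part of what the source reports. "The series", "measured", "known", "first", "only" and "open" are said of these compounds alone.

The compounds measured so far, with their numbers in an assay on Sf9 cells for inhibition of serine/threonine-protein kinase 4 (Homo sapiens), read by luminescence and ADP-Glo, with a stated time of 1 h, in the presence of a further agent that is not named here; on this read-out lower numbers stand for stronger inhibition and higher numbers for weaker inhibition:

compound 1 `CN1C(=O)C(C2CC2)N(C)c2nc(Nc3ccc(S(N)(=O)=O)cc3)ncc21`: 136 nM
compound 2 `CN1C(=O)C(CC2CC2)N(C)c2nc(Nc3ccc(S(N)(=O)=O)cc3)ncc21`: 211 nM
compound 3 `CN1C(=O)C(c2ccccc2Cl)N(C)c2nc(Nc3ccc(S(N)(=O)=O)cc3)ncc21`: 129 nM

On these numbers compound 3 carries the lowest value, yet the step of a 1.1-fold lower number from compound 1 to compound 3 (0.02 log units; within the scatter) and the step of a 1.6-fold lower number from compound 2 to compound 3 (0.21 log units; within the scatter) both lie within the scatter, so the three compounds cannot be told apart. Compound 4 `CCc1ccccc1C1C(=O)N(C)c2cnc(Nc3ccc(S(N)(=O)=O)cc3)nc2N1C` has not been measured. It differs from compound 3 in one place: ethyl in place of chloro on an aromatic carbon. Going by the values given here, no measured step alters a group on that aromatic ring; the steps seen so far exchange the whole group on the saturated ring carbon, and all of them stayed within the scatter. By that evidence the change is expected to bring no step beyond the scatter. For compound 4 the expected step in this assay is a 1.1-fold higher number from compound 3 to compound 4 (0.04 log units; within the scatter). Compound 4 is therefore estimated at 140 nM, with a range from 60 nM to 330 nM.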

Compound 4, half-maximal inhibitory concentration: 51 nM
Beside the measured number, compound 4's estimate is 2.7-fold (0.44 log units) above it, outside the stated range (below it).
By their numbers in this assay, from the lowest: compound 4; then compounds 3, 1 and 2 (each within the scatter of the next).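

In this assay, going by these compounds alone, ethyl in place of chloro on the aromatic ring gives the first step beyond the scatter, a 2.5-fold lower number from compound 3 to compound 4 (0.40 log units; beyond the scatter), so a small change on this ring can matter even though exchanging the whole group among compound 1, compound 2 and compound 3 did not. The 2-ethylphenyl group also stands apart from the smaller groups on the saturated ring carbon, with a 4.1-fold lower number from compound 2 to compound 4 (0.62 log units; beyond the scatter) and a 2.7-fold lower number from compound 1 to compound 4 (0.43 log units; beyond the scatter), which 2-chlorophenyl did not achieve. Nothing given here bears on the reason for these steps. The compounds shown leave open how a propyl chain, a methoxy group or an amine would fare at this place on the ring.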